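The compounds below may be only part of what the source reports. "The series", "measured", "known", "first", "only" and "open" are said of these compounds alone.

In a functional assay on MCF7 cells (Homo sapiens) for antiproliferative activity, read by MTT assay, with a stated time of 48 h (on this read-out lower numbers stand for stronger inhibition and higher numbers for weaker inhibition), compound 1 (`c1ccc(-c2nn(-c3ccccc3)cc2-c2nc3ccccc3[nH]2)cc1`) gives 3190 nM, compound 2 (`Fc1ccc2[nH]c(-c3cn(-c4ccccc4)nc3-c3ccccc3)nc2c1`) gives 2430 nM and compound 3 (`Fc1ccc(-c2nn(-c3ccccc3)cc2-c2nc3ccccc3[nH]2)cc1`) gives 3200 nM. These three values lie within the scatter of one another, so compound 3 is not separated from either neighbour.

Compound 4 (`Fc1ccc(-c2nn(-c3ccccc3)cc2-c2nc3cc(F)ccc3[nH]2)cc1`) differs from compound 3 by fluoro in place of hydrogen on an aromatic carbon. This is fluoro in place of hydrogen on an aromatic carbon of a six-membered aromatic ring of carbon only, part of a fused or bridged system of two rings.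

Among the measured compounds shown here, two measured steps bear on this change. The closer precedent is a 1.3-fold lower number from compound 1 to compound 2 (0.12 log units; within the scatter), where fluoro also enters the fused system. The other is a 1.0-fold higher number from compound 1 to compound 3 (0.00 log units; within the scatter), where fluoro enters elsewhere in the molecule, and compound 3 already carries that fluoro. For the measured compounds named here, neither step leaves the scatter, and the series holds no measured compound with both fluoro groups, so any interplay between them remains untested.

No shift beyond the scatter is therefore expected in this assay. The expected step is a 1.3-fold lower number from compound 3 to compound 4 (0.11 log units; within the scatter), a size that stays within the scatter. For compound 4 the estimate is 2500 nM, with an expected range from 1300 nM to 4800 nM.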

Compound 4, half-maximal inhibitory concentration: 950 nM
Estimate against measurement, compound 4: 2.6-fold (0.42 log units) above; the measured number lies below the stated range.
By their numbers in this assay, from the lowest: compound 4; then compounds 2, 1 and 3 (each within the scatter of the next).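

In this assay, among the compounds shown here, carrying both fluoro groups is the first change to leave the scatter, with a 3.4-fold lower number from compound 3 to compound 4 (0.53 log units; beyond the scatter) and a 2.6-fold lower number from compound 2 to compound 4 (0.41 log units; beyond the scatter). Fluoro on the fused system therefore appears to count for more when the second fluoro is already present, but this dependence on the core is not established, as the two steps for this change stay within the scatter of each other: the same change on two cores in this assay, a 1.3-fold lower number (0.12 log units; within the scatter) from compound 1 to compound 2 and a 3.4-fold lower number (0.53 log units; beyond the scatter) from compound 3 to compound 4, 2.6-fold (0.41 log units) apart, within the scatter of two such steps. The same caution applies to the fluoro outside the fused system: the same change on two cores in this assay, a 1.0-fold higher number (0.00 log units; within the scatter) from compound 1 to compound 3 and a 2.6-fold lower number (0.41 log units; beyond the scatter) from compound 2 to compound 4, 2.6-fold (0.41 log units) apart, within the scatter of two such steps.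

The compounds shown cannot tell whether the lower number of compound 4 is specific to fluoro, since every change here is hydrogen to fluoro; chloro, methyl, methoxy or an amine on the same aromatic carbon, with the core of compound 3 kept, would test this. Going by these compounds, whether the pairing of the two groups holds at other carbons of the fused system, or in cell lines other than this one, also remains open.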